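The source may report more compounds than this note shows. Statements on the series, on what has been measured and on what is new or still open speak of the compounds shown alone.

Measured in a functional assay on CHO cells for agonist activity at adenosine receptor A1 (Homo sapiens), read by fluorescence and ERK phosphorylation, with stated times of 30 min and 1.5 h, tested at 3 uM; on this read-out lower numbers stand for a weaker effect and higher numbers for a stronger effect at the one concentration tested:
compound 1 `Nc1scc(-c2cccc(C(F)(F)F)c2)c1C(=O)c1ccccc1`, 83%;
compound 2 `Nc1scc(-c2ccc(I)cc2)c1C(=O)c1ccccc1`, 51%;
compound 3 `Nc1scc(-c2cccc(C(F)(F)F)c2)c1C(=O)c1ccc(Cl)cc1`, 64%.

Compound 3 stands second of the three in this assay: compound 1 lies above it, the step of a number 19 percentage points lower from compound 1 to compound 3 (beyond the scatter) being beyond the scatter, and compound 2 lies below it, also beyond the scatter. Compound 4 `Nc1scc(-c2cccc(Br)c2)c1C(=O)c1ccc(Cl)cc1` differs from compound 3 by bromo in place of trifluoromethyl on an aromatic carbon. Within the data shown here, no measured pair isolates this change; the only measured step, a number 19 percentage points lower from compound 1 to compound 3 (beyond the scatter), concerns the other ring, and compound 2, a halogen-bearing analogue without a single-change partner here, gives 51%. With bromo replacing a larger group, a small to modest decrease is expected, a number 9 percentage points lower from compound 3 to compound 4 (within the scatter), with wide uncertainty. Compound 4 is therefore estimated at 55%, between 35% and 75%.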

Compound 4, a percentage reported as activity, at one concentration (the size of the read-out at that concentration, not a potency): 62%
For compound 4 the middle estimate is 7 percentage points below the measured one; low and high end bracket the measured number.
By their numbers in this assay, from the lowest: compound 2; then compounds 4 and 3 (each within the scatter of the next); then compound 1.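

In this assay, bromo in place of trifluoromethyl on an aromatic carbon, meta to a large group, gives a number 2 percentage points lower from compound 3 to compound 4 (within the scatter). This is the only single-change pair shown at this position, and it shows that, with the chloro of compound 3 kept, the two groups cannot be told apart at the one concentration tested. Nothing shown accounts for this result. Going by these compounds, whether the same exchange holds on the core of compound 1, without that chloro, remains open. Also open, on these data alone, is how an amine, a carboxylic acid or a longer chain would read at this position.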